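Cytotoxicity notes: furan-2-yl to 4-methylphenyl on the shared core

The source may hold more compounds than are shown below. What is called first, only, known or untested is meant among the compounds shown, and "the series" means these compounds.

Measured so far:
compound 1, `C/C(=N\NC(=O)CC#N)c1ccc(NS(=O)(=O)c2ccc(Cl)cc2)cc1`, 6500 nM
compound 2, `CCOC(=O)c1c(-c2ccco2)c(C#N)c(=O)n(/N=C(\C)c2ccc(NS(=O)(=O)c3ccc(Cl)cc3)cc2)c1N`, 8800 nM

In a functional assay on HepG2 cells (Homo sapiens) for cytotoxicity, read by sulforhodamine B assay, with stated times of 2 h, 17.73 min and 48 h (on this read-out higher numbers stand for weaker inhibition and lower numbers for stronger inhibition), compound 2 gives 8800 nM, and compound 1 gives 6500 nM; the two numbers lie within the scatter of each other, so no order between them can be read from this pair. Going by the values given here, no single-change step between measured compounds is available in this assay.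

Compound 3, `CCOC(=O)c1c(-c2ccc(C)cc2)c(C#N)c(=O)n(/N=C(\C)c2ccc(NS(=O)(=O)c3ccc(Cl)cc3)cc2)c1N`, remains to be measured. It differs from compound 2 by 4-methylphenyl in place of furan-2-yl on an aromatic carbon. Nothing measured in the series speaks to this exchange, so the expected step of a 1.1-fold lower number from compound 2 to compound 3 (0.04 log units; within the scatter) is set at none beyond the scatter, with no direction preferred. The expected result for compound 3 in this assay is 8000 nM, within a range from 3500 nM to 18000 nM.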

Compound 3, half-maximal inhibitory concentration: 7300 nM
Beside the measured number, compound 3's estimate is 1.1-fold (0.04 log units) above it; the range from low to high includes it.
By their numbers in this assay, from the lowest: compounds 1, 3 and 2 (each within the scatter of the next).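

In this assay the exchange of furan-2-yl for 4-methylphenyl gives a 1.2-fold lower number from compound 2 to compound 3 (0.08 log units; within the scatter) on the aromatic carbon opposite the ring nitrogen, a step within the scatter. This position thus carries either a five-membered aromatic ring with a hetero atom or a six-membered aromatic ring of carbon only, and the hydrogen-bond acceptor of the furan-2-yl group can go, with no difference that can be read in this measure of cytotoxicity. No available evidence bears on this result.

Whether any group on this carbon can move the number beyond the scatter stays open, since only these two aromatic groups are shown there. A carboxylic acid, an amine or a longer alkyl chain at the same place would extend the comparison to non-aromatic groups.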